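Methylsulfanyl replaces a triflate on the indole agonist

The compounds below may be only part of what the source reports. "The series", "measured", "known", "first", "only" and "open" are said of these compounds alone.

The series starts from compound 1 `Cc1[nH]c2ccccc2c1C1=CCNCC1`, which in an in vitro functional assay on BHK cells for agonist activity at 5-hydroxytryptamine receptor 6 (Homo sapiens), read by cAMP accumulation, with a stated time of 45 min (a higher number here means that more compound is needed for the effect, a lower number that less compound is needed), gives 1100 nM. Compound 2 `Cc1[nH]c2ccc(OS(=O)(=O)C(F)(F)F)cc2c1C1=CCNCC1` carries a ((trifluoromethyl)sulfonyl)oxy group on an aromatic carbon of the core, and in this assay compound 2 gives 32 nM. Within the data shown here, the step of a 34-fold lower number from compound 1 to compound 2 (1.54 log units; beyond the scatter) shows that a group at this place changes the read-out strongly, and compound 2 stands lowest of the two numbers measured, with compound 1 as its only neighbour.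

Compound 3 `CSc1ccc2[nH]c(C)c(C3=CCNCC3)c2c1` is not yet measured. It differs from compound 2 by methylsulfanyl in place of ((trifluoromethyl)sulfonyl)oxy on an aromatic carbon. Among the measured compounds shown here, the only step that bears on this change is a 34-fold lower number from compound 1 to compound 2 (1.54 log units; beyond the scatter), and it concerns the arrival of a group at this place rather than an exchange of one group for another. A methylsulfanyl group keeps the place occupied, so compound 3 is expected to lie nearer compound 2 than compound 1, with a modest rise in the number as the likelier direction: the expected step is a 1.6-fold higher number from compound 2 to compound 3 (0.19 log units; within the scatter). Compound 3 is therefore estimated at 50 nM, within a range from 10 nM to 250 nM.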

Compound 3, half-maximal effective concentration: 6.6 nM
The estimate for compound 3 lay 7.6-fold (0.88 log units) above the measured number, outside the stated range (below it).
By their numbers in this assay, from the lowest: compound 3; then compound 2; then compound 1.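

Exchanging the ((trifluoromethyl)sulfonyl)oxy group for methylsulfanyl moves the number further in the same direction (a 4.8-fold lower number from compound 2 to compound 3 (0.69 log units; beyond the scatter)), so the low number of compound 2 does not depend on that particular group. The entering group has 2 heavy atoms against the 8 that leave, and measured against hydrogen it gives the largest step seen at this place (a 170-fold lower number from compound 1 to compound 3 (2.22 log units; beyond the scatter)), which leaves compound 3 lowest of the three in this assay. No measurement available here accounts for the difference between the two groups.

The compounds shown leave open whether the sulfur itself matters, since a methoxy group or an ethyl group at this place would test that directly. They also leave open how far the trend extends, whether to a longer chain on the sulfur, such as ethylsulfanyl, or to an amine on the same aromatic carbon.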